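Extending the Methyl on the Core Nitrogen

The source may hold more compounds than are shown below. What is called first, only, known or untested is meant among the compounds shown, and "the series" means these compounds.

Compound 2 `Cc1nn(C)c2c1C(c1cccc(C(F)(F)F)c1)=NCCN2` is a close relative of compound 1 `Cc1nn(C)c2c1C(c1cccc(Cl)c1)=NCCN2`. In a functional assay on the whole organism for positive allosteric modulation, with Rattus norvegicus as the target (a higher number here means that more compound is needed for the effect, a lower number that less compound is needed), compound 1 gives 0.63 mg/kg, and compound 2 gives 0.63 mg/kg, so compound 2 stands level with compound 1. Going by the values given here, the only measured step, no change at the digits printed from compound 1 to compound 2 (within the scatter), left the minimum effective dose where it was. Compound 3 `CCn1nc(C)c2c1NCCN=C2c1cccc(C(F)(F)F)c1` differs from compound 2 by methyl in place of hydrogen on a saturated chain carbon bound to an aromatic nitrogen, which, cut one bond further out, reads methyl to ethyl. Among the compounds with values here, no measured step touches this place; the one available step concerns trifluoromethyl in place of chloro on an aromatic carbon and bears on it only loosely, by showing that a small change elsewhere on the shared core left the dose unchanged. The step from compound 2 to compound 3 is therefore expected to stay near zero, a 1.3-fold higher number from compound 2 to compound 3 (0.10 log units; within the scatter), with some room for a modest loss. Compound 3 is estimated at 0.8 mg/kg, within a range from 0.3 mg/kg to 2.5 mg/kg.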

Compound 3, minimum effective dose: 0.63 mg/kg
Estimate against measurement, compound 3: 1.3-fold (0.10 log units) above; the measured number falls inside the stated range.
By their numbers in this assay, from the lowest: compounds 1, 2 and 3 (each within the scatter of the next).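

In this assay, methyl in place of hydrogen on a saturated chain carbon bound to an aromatic nitrogen brought no change at the digits printed from compound 2 to compound 3 (within the scatter). Going by these compounds alone, compound 1 and compound 2 differ only on an aromatic carbon, so this is the first reading at this second place, and it shows that methyl can become ethyl here without moving the minimum effective dose beyond the usual scatter. Nothing available explains why this change leaves the dose where it was.

Only methyl and ethyl are shown at this place, so it remains open whether a longer chain such as propyl, or a chain ending in an amine or a carboxylic acid, would hold the dose as well. All three compounds print the same dose, so they do not reveal which change to the shared core would shift it in either direction.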